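Amine deprotection across a series sitting at the limit

The source may hold more compounds than are shown below. What is called first, only, known or untested is meant among the compounds shown, and "the series" means these compounds.

Measured so far:
compound 1, `CC(C)[C@H](NC(=O)c1cc(Cl)ccc1OCCCNC(=O)OC(C)(C)C)C(=O)Nc1ccc([N+](=O)[O-])cc1Cl`. In a functional assay on MCF7 cells (Homo sapiens) for inhibition, read by MTT assay, with a stated time of 72 h (a lower number here means a stronger inhibitor, a higher number a weaker inhibitor), compound 1 gives > 10000 nM, a limit of the assay.
compound 2, `CC(C)[C@H](NC(=O)c1cc(Cl)ccc1OCCCN)C(=O)Nc1ccc([N+](=O)[O-])cc1Cl`. In this assay compound 2 gives > 10000 nM, a limit.
compound 3, `CC(C)(C)OC(=O)CC[C@H](NC(=O)c1cc(Cl)ccc1OCCNC(=O)OC(C)(C)C)C(=O)Nc1ccc([N+](=O)[O-])cc1Cl`. In this assay compound 3 gives > 10000 nM, a limit.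

The change between the first two is hydrogen in place of tert-butoxycarbonyl on an amine nitrogen, and it gives a step that the two limits leave unreadable from compound 1 to compound 2. Both values rest on (the limit of > 10000 nM in this assay, at which 3 of the 3 values shown sit). Compound 4, `CC(C)(C)OC(=O)CC[C@H](NC(=O)c1cc(Cl)ccc1OCCN)C(=O)Nc1ccc([N+](=O)[O-])cc1Cl`, remains to be measured; it stands to compound 3 as compound 2 stands to compound 1, the same change, (hydrogen in place of tert-butoxycarbonyl on an amine nitrogen). The difference between the two cores, compound 1 against compound 3, is not broken down here. Because the limit of > 10000 nM in this assay, at which 3 of the 3 values shown sit, holds for every measured compound, an equally unreadable step is expected, a step that the limit leaves unreadable from compound 3 to compound 4. Compound 4 is expected to give 15000 nM, estimated between 5000 nM and 50000 nM, most probably again reported only as a limit.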

Compound 4, half-maximal inhibitory concentration: 3080 nM
Estimate against measurement, compound 4: 4.9-fold (0.69 log units) above; the measured number lies below the stated range.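

In this assay, replacing tert-butoxycarbonyl with hydrogen on the amine nitrogen gives an at least 3.2-fold lower number from compound 3 to compound 4 (0.51 log units; beyond the scatter), so on the core of compound 3 the change gives a number that can be read. On the core of compound 1 the same change cannot be read, because both values there rest on a limit: the limit of > 10000 nM in this assay, at which 3 of the 4 values shown sit. The change is therefore shown to lower the number on one core only, and the data neither confirm nor rule out that it carries over to the other.

Which of the differences between the two cores matters remains open. Also open, on these data alone, is how a carboxylic acid in place of the tert-butyl ester of compound 4, or a methylated amine in place of its amino group, would read.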